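Swapping a Fluoro for tert-Butyl on Compound 2

This account rests on a few compounds, and the source may have more. Where it says the series, first, only, none or still open, it means among the compounds named here.

Two measured compounds share one core and differ only in a group on a phenyl ring attached through sulfur. Compound 1 `OC[C@H]1O[C@@H](n2cnc3c(CSc4ccccc4F)ncnc32)[C@H](O)[C@@H]1O` gives 355 nM in an assay on isolated protein for binding affinity to Equilibrative nucleoside transporter 1 (Homo sapiens) (a higher number here means a weaker inhibitor, a lower number a stronger inhibitor), and compound 2 `OC[C@H]1O[C@@H](n2cnc3c(CSc4ccc(F)cc4)ncnc32)[C@H](O)[C@@H]1O` gives 158 nM. Going by the values given here, the single step so far is a 2.2-fold lower number from compound 1 to compound 2 (0.35 log units; beyond the scatter). Compound 2 therefore holds the lowest of the two numbers, with compound 1 nearest and separated from it by a step beyond the scatter.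

Compound 3 `CC(C)(C)c1ccc(SCc2ncnc3c2ncn3[C@@H]2O[C@H](CO)[C@@H](O)[C@H]2O)cc1` keeps everything of compound 2 except one spot: tert-butyl in place of fluoro on an aromatic carbon, on an aromatic carbon of a six-membered aromatic ring of carbon only, para to a large group. Among the compounds with values here, the one measured step concerns where a fluoro sits, not what stands in its place, so it says little about this exchange. No direction beyond the scatter is expected. Compound 3 is estimated at 130 nM in this assay, within 40 nM to 450 nM. The expected step is a 1.2-fold lower number from compound 2 to compound 3 (0.08 log units; within the scatter).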

Compound 3, half-maximal inhibitory concentration: 331000 nM
Beside the measured number, compound 3's estimate is 2500-fold (3.41 log units) below it; measured number outside the range, above it.
By their numbers in this assay, from the lowest: compound 2; then compound 1; then compound 3.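

In this assay, the ring carbon para to a large group turns out to be highly sensitive to what stands on it: tert-butyl in place of fluoro gives a far larger change (a 2100-fold higher number from compound 2 to compound 3 (3.32 log units; beyond the scatter)) than the modest one seen when only the fluoro's location differed (a 2.2-fold lower number from compound 1 to compound 2 (0.35 log units; beyond the scatter)). The comparison with the other fluoro compound points the same way (a 930-fold higher number from compound 1 to compound 3 (2.97 log units; beyond the scatter)), which leaves compound 3 as the weakest inhibitor of the three by a wide margin. Nothing available here explains why this exchange costs so much.

As far as these compounds go, whether a methyl, a chloro or a methoxy at this place would stay close to compound 2 or fall toward compound 3 remains open. So does the outcome for a group of a different kind, such as an amine or a carboxylic acid.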